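The source may report more compounds than this note shows. Statements on the series, on what has been measured and on what is new or still open speak of the compounds shown alone.

Of the compounds shown here, three built on one shared core have been measured in a functional assay on MCF7 cells (Homo sapiens) for cytotoxicity, read by MTT assay, with a stated time of 72 h; a lower number here means a stronger inhibitor, a higher number a weaker inhibitor. Compound 1 `CN1[C@@H]2c3[nH]c4ccccc4c3C[C@H]1[C@H](C#N)N1[C@@H](CN3C(=O)c4ccccc4C3=O)c3[nH]c4ccccc4c3C[C@@H]21` gives 610 nM. Compound 2 `CN1[C@@H]2c3[nH]c4ccccc4c3C[C@H]1[C@H](C#N)N1[C@@H](CNC(=O)c3cccc(C(F)(F)F)c3)c3[nH]c4ccccc4c3C[C@@H]21` gives 110 nM. Compound 3 `CN1[C@@H]2c3[nH]c4ccccc4c3C[C@H]1[C@H](C#N)N1[C@@H](CNC(=O)c3cccc4c3CCCC4)c3[nH]c4ccccc4c3C[C@@H]21` gives 4470 nM, the highest of the three numbers; its nearest neighbour is compound 1 and its furthest is compound 2, and both of those gaps lie beyond the scatter. The step to compound 4 `CN1[C@@H]2c3[nH]c4ccccc4c3C[C@H]1[C@H](C#N)N1[C@@H](CNC(=O)c3cc4ccccc4[nH]3)c3[nH]c4ccccc4c3C[C@@H]21` is 1H-indol-2-yl in place of 1,2,3,4-tetrahydronaphthalen-5-yl on a carbonyl carbon. Among the compounds with values here, only one measured step changes this same position on the carbonyl carbon: a 41-fold higher number from compound 2 to compound 3 (1.61 log units; beyond the scatter), a large move toward weaker inhibition. That single comparison shows that the group on this carbonyl carbon can swing the number widely, and compound 4 carries the 1H-indol-2-yl group there in place of the group that gave the weakest result, so a move back toward lower numbers is expected in this assay, though its size is uncertain. The step is estimated as a 5.0-fold lower number from compound 3 to compound 4 (0.70 log units; beyond the scatter). Compound 4 is therefore estimated at 900 nM, with a likely range from 200 nM to 4000 nM.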

Compound 4, half-maximal inhibitory concentration: 9780 nM
Compound 4: the middle estimate sits 11-fold (1.04 log units) below what was measured, and the stated range ends below it.
By their numbers in this assay, from the lowest: compound 2; then compound 1; then compound 3; then compound 4.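

In this assay, the 1H-indol-2-yl group did not bring the number back down, and the step was instead a 2.2-fold higher number from compound 3 to compound 4 (0.34 log units; beyond the scatter). Set against the 3-(trifluoromethyl)phenyl group, the gap grows to an 89-fold higher number from compound 2 to compound 4 (1.95 log units; beyond the scatter), so both groups with a second ring on this carbonyl carbon lie far above the group with a single ring, though compound 1, which has a different linking group, also carries two rings and gives a lower number, with a 16-fold higher number from compound 1 to compound 4 (1.21 log units; beyond the scatter). Nothing available explains why these groups on the carbonyl carbon differ so widely.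

As far as these compounds go, it remains open whether the low number of compound 2 belongs to the trifluoromethyl group or to the single six-membered aromatic ring that carries it, which a plain phenyl or a 3-chlorophenyl group would help to separate. A 1-methyl-1H-indol-2-yl group would test whether the hydrogen on the indole nitrogen plays any part in the step from compound 3.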